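Replacing the oxane ring in compound 2 with a dimethylcyclohexyl

The source may report more compounds than this note shows. Statements on the series, on what has been measured and on what is new or still open speak of the compounds shown alone.

Measured so far:
Compound 1, `Cc1cc(NC(=S)Cn2nnc(-c3ccccc3)n2)n(C2CCCCC2)n1`: 623 nM
Compound 2, `Cc1cc(NC(=O)Cn2nnc(-c3ccccc3)n2)n(C2CCOCC2)n1`: 435 nM

In an assay on HEK293 cells for activation of Kir3.1/Kir3.2 (Homo sapiens), read by thallium flux (a lower number here means that less compound is needed, a higher number that more compound is needed for the effect), compound 2 gives 435 nM. Compound 1, which gives 623 nM in this assay, differs from compound 2 in two places at once, and its number lies within the usual scatter of that of compound 2, so the two cannot be told apart by potency.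

Compound 3, `Cc1cc(NC(=O)Cn2nnc(-c3ccccc3)n2)n(C2CCC(C)(C)CC2)n1`, is compound 2 with one change: 4,4-dimethylcyclohexyl in place of oxan-4-yl on an aromatic nitrogen. Among the measured compounds shown here, no measured pair isolates this change. Compound 1 cannot serve as a guide: its ring and its linker both differ from those of compound 2. The expected step of a 1.1-fold higher number from compound 2 to compound 3 (0.06 log units; within the scatter) in this assay is therefore small, in either direction, and not beyond the scatter. Compound 3 is estimated at 500 nM, with a range from 180 nM to 1500 nM.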

Compound 3, half-maximal effective concentration: > 221 nM
Compound 3 ended at the assay's limit; the forecaster's own chance of this, stated with the estimate: 5%; the middle value is on the limit's open side.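

Compound 3 gives > 221 nM, which is a limit of the assay and not a number. Among the compounds shown here, no step from compound 2 to compound 3 can be read from it. Going by these compounds, whether 4,4-dimethylcyclohexyl in place of oxan-4-yl changes the amount of compound needed, and by how much, stays open.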